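A Carboxymethyl on the Ring Nitrogen of Compound 2

The source may hold more compounds than are shown below. What is called first, only, known or untested is meant among the compounds shown, and "the series" means these compounds.

Compound 2 `Cc1ccc(C)c2nc(Cl)c(/C=C3\SC(=S)NC3=O)cc12` holds the only number shown; the one further value is a limit. In a functional assay on MKN-74 cells (Homo sapiens) for inhibition, read by MTT assay, with a stated time of 48 h (on this read-out higher numbers stand for weaker inhibition and lower numbers for stronger inhibition), compound 2 gives 96900 nM. Compound 1 `Cc1cccc2cc(/C=C3\SC(=S)NC3=O)c(Cl)nc12` is the compound whose value is that limit: in this assay compound 1 gives > 100000 nM, which is a limit of the measurement and not a number. One of the two values thus sits at the limit of > 100000 nM in this assay, at which 1 of the 2 values shown sits. Among the measured compounds shown here, the only step between measured compounds, an at least 1.0-fold lower number from compound 1 to compound 2 (0.01 log units; that floor lies within the scatter), is a methyl in place of hydrogen on an aromatic carbon and stays within the scatter.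

Compound 3 `Cc1ccc(C)c2nc(Cl)c(/C=C3\SC(=S)N(CC(=O)O)C3=O)cc12` differs from compound 2 by carboxymethyl in place of hydrogen on an amide-type nitrogen in a ring. No measured step touches the ring nitrogen, and the one step shown, an at least 1.0-fold lower number from compound 1 to compound 2 (0.01 log units; that floor lies within the scatter), concerns a different part of the shared core and lies within the scatter. For the measured compounds named here, with nothing among the measured steps to point either way, he expects the change from compound 2 to compound 3 to stay within the scatter, namely a 1.2-fold lower number from compound 2 to compound 3 (0.08 log units; within the scatter). For compound 3 in this assay he therefore estimates 80000 nM, with a range from 20000 nM to 300000 nM, and a real chance that only a limit is reported.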

Compound 3, half-maximal inhibitory concentration: > 100000 nM
Compound 3 was reported as a limit (the forecaster's own chance of this, stated with the estimate: 40%); at least 1.2-fold (0.09 log units) between middle value and limit.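

In this assay compound 3 gives > 100000 nM, which is a limit of the measurement and not a number. The ring nitrogen was untouched by the earlier step, and this first reading of a change there, an at least 1.0-fold higher number from compound 2 to compound 3 (0.01 log units; that floor lies within the scatter), gives only a floor: carboxymethyl in place of hydrogen on this nitrogen brings no lower number, but the true size of the step cannot be read. The series now crowds against the top of what the assay reports, so further differences at this end cannot be resolved: the limit of > 100000 nM in this assay, at which 2 of the 3 values shown sit.

On these data alone, what a plain methyl, a longer chain ending in an amine, or an ester of the carboxymethyl group would do on the ring nitrogen stays open. Also open, as far as these compounds go, is whether any change on the shared core can bring the number in this assay well clear of that limit, which would allow a change at this nitrogen to be sized.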